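The source may hold more compounds than are shown below. What is called first, only, known or untested is meant among the compounds shown, and "the series" means these compounds.

The measured compounds in an ADME assay on Raji cells (Homo sapiens) for cytotoxicity, with a stated time of 72 h; on this read-out lower numbers stand for an effect already at smaller amounts and higher numbers for an effect only at larger amounts of compound:

Compound 1, `Cc1cc(NC(=O)Nc2ccc(C)c(Cl)c2)c2ccccc2n1`, gives a limit of the assay, > 25000 nM.
Compound 2, `Cc1cc(NC(=O)Nc2cccc(Cl)c2)c2ccccc2n1`, gives 18000 nM.
Compound 3, `Cc1cc(NC(=O)Nc2cc(Cl)cc(Cl)c2)c2ccccc2n1`, gives a limit of the assay, > 25000 nM.

Compound 2 stands alone among the three: it is the only one whose read-out in this assay comes back as a number, while the other two stop at the limit described by the limit of > 25000 nM in this assay, at which 2 of the 3 values shown sit. The step from compound 1 to compound 2, an at least 1.3-fold lower number from compound 1 to compound 2 (0.14 log units; that floor lies within the scatter), removes a methyl; the step from compound 2 to compound 3, an at least 1.3-fold higher number from compound 2 to compound 3 (0.14 log units; that floor lies within the scatter), adds a chloro. Both steps are floors that sit within the scatter, so on the shared core small changes to the pendant phenyl ring have not moved the read-out further than the assay can resolve.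

Compound 4, `Cc1cc(NC(=O)Nc2cccc(F)c2)c2ccccc2n1`, follows from compound 2 by the change (fluoro in place of chloro on an aromatic carbon). Neither measured step is this exact exchange, yet both show that single substituent changes on this ring leave the read-out near or at the limit. The expected step from compound 2 to compound 4 is therefore small, a 1.2-fold higher number from compound 2 to compound 4 (0.09 log units; within the scatter), with a real chance that only a limit is returned. For compound 4 the estimate in this assay is 22000 nM, ranging from 10000 nM to 50000 nM.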

Compound 4, half-maximal effective concentration: > 25000 nM
Compound 4 ended at the assay's limit; the forecaster's own chance of this, stated with the estimate: 45%; middle value at least 1.1-fold (0.05 log units) from the limit.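

Replacing the chloro of the 3-chlorophenyl group with fluoro, at this place meta to a large group, gives an at least 1.3-fold higher number from compound 2 to compound 4 (0.14 log units; that floor lies within the scatter) in this assay. Going by these compounds alone, that step is only a floor, so the exchange of one halogen for the other has no measured size here, and compound 2 remains the only compound of the four with a number rather than a limit. The chloro-to-fluoro exchange therefore behaves like the two earlier changes on the pendant ring in that it resolves no difference, and the read-outs now gather even more at one end of the range: the limit of > 25000 nM in this assay, at which 3 of the 4 values shown sit.

The compounds shown leave open whether any other group at this place, such as an amine, a carboxylic acid or a longer chain, would bring a read-out clearly beyond the scatter from compound 2. They also leave open how far past the limit compound 1, compound 3 and compound 4 lie, and whether changes to the shared core, rather than to the pendant ring, would move the read-out.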